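A few compounds are considered here, and "the series" means these few. Any claim that something is new, unique, unknown or untested is made for them only; others in the source may bear on it.

Measured compounds:
Compound 1 `C[C@@H]1CC[C@H]2C(=O)[C@H]3O[C@]3(C)CC[C@@H]3O[C@@]3(C)CC[C@]1(C)[C@H]2CO`: 30000 nM
Compound 2 `CC(=O)OC[C@H]1[C@H]2CC[C@@H](C)[C@]1(C)CC/C(C)=C/CC[C@@]1(C)O[C@@H]1C2=O`: 410 nM

In an assay (Oryctolagus cuniculus) for inhibition of platelet-activating factor receptor (Cavia porcellus) (on this read-out higher numbers stand for weaker inhibition and lower numbers for stronger inhibition), compound 2 gives 410 nM, the lowest of the two numbers shown. Compound 1 gives 30000 nM, a higher number that lies beyond the usual scatter, so compound 2 stands clearly apart from it. For the measured compounds named here, no pair of measured compounds differs in only one place, so no measured single step is available as a guide.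

Compound 3 `COC(=O)OC[C@H]1[C@H]2CC[C@@H](C)[C@]1(C)CC/C(C)=C/CC[C@@]1(C)O[C@@H]1C2=O` differs from compound 2 in one place: methoxy in place of methyl on a carbonyl carbon. Nothing measured here speaks directly to such a change at this position. The author expects a step of a 1.2-fold higher number from compound 2 to compound 3 (0.09 log units; within the scatter), small, most likely within the scatter of repeated measurements, with no firm direction to it. Compound 3 is therefore estimated at 500 nM, with a range from 150 nM to 1600 nM.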

Compound 3, half-maximal inhibitory concentration: 26 nM
The estimate for compound 3 lay 19-fold (1.28 log units) above the measured number; the whole stated range lies above it.
By their numbers in this assay, from the lowest: compound 3; then compound 2; then compound 1.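

In this assay the exchange of acetoxymethyl for ((methoxycarbonyl)oxy)methyl gives a 16-fold lower number from compound 2 to compound 3 (1.20 log units; beyond the scatter) and so shows that this place on the shared core is not a silent one. Methoxy in place of methyl on a carbonyl carbon, a change of only one carbon-bound group, moves the number well beyond the scatter and towards stronger inhibition. No supporting measurement bears on why this step is so large.

Still open, from the compounds shown here alone, is how ethoxy or dimethylamino on the same carbonyl carbon would read out, and so whether the step belongs to the entering oxygen or to the methoxy group as a whole. Compound 1 differs from compound 2 and compound 3 in more than one place, so these compounds do not show what its separate changes contribute.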